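This account rests on a few compounds, and the source may have more. Where it says the series, first, only, none or still open, it means among the compounds named here.

Of the compounds shown here, two have been measured so far. In a functional assay on MCF7 cells (Homo sapiens) for antiproliferative activity (on this read-out higher numbers stand for weaker inhibition of growth and lower numbers for stronger inhibition of growth), compound 1 (`COc1ccc(-c2nc3ccccc3s2)cc1OC`) gives 52700 nM. In this assay, compound 2 (`COc1ccc(-c2nc3cc(F)ccc3s2)cc1I`) gives 820 nM, the lower of the two numbers, and the gap between them lies beyond the usual scatter. Compound 3 (`COc1ccc(-c2nc3cc(F)ccc3s2)cc1OC`) has not yet been measured in this assay. In going from compound 2 to compound 3, methoxy takes the place of iodo on an aromatic carbon, ortho to a methoxy group and meta to a large group: methoxy in place of iodo on an aromatic carbon. Among the measured compounds shown here, no measured pair isolates this change, so any expectation is uncertain and the range must be wide. A large move toward stronger inhibition of growth, beyond the scatter, is expected, and the estimated step is an 820-fold lower number from compound 2 to compound 3 (2.91 log units; beyond the scatter). The estimated value for compound 3 is 1 nM, with an expected range from 0.05 nM to 200 nM.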

Compound 3, concentration for 50% growth inhibition: < 0.1 nM
Compound 3 ended at the assay's limit; the forecaster's own chance of this, stated with the estimate: 45%; at least 10-fold (1.00 log units) between middle value and limit.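

In this assay, the position ortho to a methoxy group and meta to a large group proves highly sensitive to its substituent: methoxy in place of iodo on this aromatic carbon gives an at least 8200-fold lower number from compound 2 to compound 3 (3.91 log units; beyond the scatter). With both methoxy groups kept, fluoro in place of hydrogen on an aromatic carbon of the shared core also gives a large change, an at least 520000-fold lower number from compound 1 to compound 3 (5.72 log units; beyond the scatter), so this single replacement matters as well. The value of compound 3 is a limit of the assay and not a number, so the full size of both steps remains unknown: the limit of < 0.1 nM in this assay, at which 1 of the 3 values shown sits.

From the compounds shown here alone, how an ethoxy group, a hydroxy group or an amine would compare with methoxy and iodo on this carbon remains open. Also open, going by these compounds, is whether fluoro in place of hydrogen would give a similar step with iodo on this carbon.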